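A few compounds are considered here, and "the series" means these few. Any claim that something is new, unique, unknown or untested is made for them only; others in the source may bear on it.

Measured so far in an ADME assay on CCRF-HSB-2 cells (Homo sapiens) for cytotoxicity, with a stated time of 7 days; a lower number here means that less compound is tolerated, a higher number that more compound is tolerated:

compound 1, `C=CCOc1nc(N)nc2c1ncn2/C=C1/CC1(CO)CO`: > 20000 nM
compound 2, `COCCOc1nc(N)nc2c1ncn2/C=C1/CC1(CO)CO`: > 20000 nM
compound 3, `CC(C)Sc1nc(N)nc2c1ncn2/C=C1/CC1(CO)CO`: 94000 nM

The value of compound 1 is a limit of this assay, not a number. The value of compound 2 is likewise a limit, so compound 2 stands at the edge of what this assay could read, as do two of the three values shown: the limit of > 20000 nM in this assay, at which 2 of the 3 values shown sit. Compound 4, `CCCCCCOc1nc(N)nc2c1ncn2/C=C1/CC1(CO)CO`, differs from compound 2 in one place: butyl in place of methoxy on a saturated chain carbon, two bonds along the chain from an oxygen on an aromatic ring. The step that touches the same chain position, a step that the two limits leave unreadable from compound 1 to compound 2, gives no readable size. The two steps that replace the whole group on the aromatic carbon, a step that the limit leaves unreadable from compound 2 to compound 3 and a step that the limit leaves unreadable from compound 1 to compound 3, are unreadable as well. Within the data shown here, no measured step therefore tells a direction for the change to butyl, and compound 3 is the only compound with a number. The estimated step from compound 2 to compound 4 is a step that the limit leaves unreadable from compound 2 to compound 4, meaning no readable change. For compound 4 the expected value in this assay is 30000 nM, within an estimated range from 8000 nM to 100000 nM.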

Compound 4, half-maximal cytotoxic concentration: > 20000 nM
Compound 4: a limit, no number; the forecaster's own chance of this, stated with the estimate: 40%; the middle value is on the limit's open side.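

In this assay compound 4 gives > 20000 nM, which is a limit and not a number. No step between compound 4 and compound 1, compound 2 or compound 3 can be read, and compound 4 joins the others at the edge of the assay: the limit of > 20000 nM in this assay, at which 3 of the 4 values shown sit.

The compounds shown leave open how far compound 1, compound 2 and compound 4 truly differ from one another.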